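Amide nitrogen substituent: methyl to isopropyl

The source may hold more compounds than are shown below. What is called first, only, known or untested is meant among the compounds shown, and "the series" means these compounds.

Compound 3 `CNC(=O)c1cc(-c2ccc(NS(=O)(=O)c3cccc(Cl)c3Cl)cc2)nc2[nH]ncc12` stands highest of the three numbers in an assay for inhibition of serine/threonine-protein kinase Sgk1 (Homo sapiens), with stated times of 30 min and 60 min, in the presence of a further agent that is not named here (a lower number here means a stronger inhibitor, a higher number a weaker inhibitor), where compound 3 gives 929 nM. Compound 1 `O=C(NC1CCN(C2CC2)C1)c1cc(-c2ccc(NS(=O)(=O)c3cccc(Cl)c3Cl)cc2)nc2[nH]ncc12` gives 610 nM, a step of a 1.5-fold higher number from compound 1 to compound 3 (0.18 log units; within the scatter). Within the data shown here, compound 2 `O=C(NC1CCN(CC2CC2)C1)c1cc(-c2ccc(NS(=O)(=O)c3cccc(Cl)c3Cl)cc2)nc2[nH]ncc12` gives 35 nM, so the step is a 27-fold higher number from compound 2 to compound 3 (1.42 log units; beyond the scatter); among the measured compounds, a 17-fold lower number from compound 1 to compound 2 (1.24 log units; beyond the scatter) is the only other change. Compound 4 `CC(C)NC(=O)c1cc(-c2ccc(NS(=O)(=O)c3cccc(Cl)c3Cl)cc2)nc2[nH]ncc12` differs from compound 3 in one place: isopropyl in place of methyl on an amide-type nitrogen. Among the measured compounds shown here, no measured step covers methyl against isopropyl on this nitrogen. The larger substituents give either a number within the scatter of compound 3 or a clearly lower one, so a small lowering at most is expected, and a 1.5-fold lower number from compound 3 to compound 4 (0.19 log units; within the scatter) is the estimated step. Compound 4 is expected at 600 nM, within 200 nM to 2000 nM.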

Compound 4, half-maximal inhibitory concentration: 17600 nM
Estimate against measurement, compound 4: 29-fold (1.47 log units) below; measured number outside the range, above it.
By their numbers in this assay, from the lowest: compound 2; then compounds 1 and 3 (each within the scatter of the next); then compound 4.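

In this assay, a clear loss appears with isopropyl on the amide-type nitrogen: a 19-fold higher number from compound 3 to compound 4 (1.28 log units; beyond the scatter) on replacing methyl. The gaps to the pyrrolidine amides, a 29-fold higher number from compound 1 to compound 4 (1.46 log units; beyond the scatter) and a 500-fold higher number from compound 2 to compound 4 (2.70 log units; beyond the scatter), show that the effect of this position does not rise or fall steadily from methyl through isopropyl to 1-cyclopropylpyrrolidin-3-yl and 1-(cyclopropylmethyl)pyrrolidin-3-yl. Nothing available accounts for the isopropyl result.

Open, as far as these compounds go, is whether ethyl or a longer straight carbon chain on this nitrogen tracks methyl or isopropyl, and whether an open-chain amine there recovers the numbers of the pyrrolidine amides.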